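The source may hold more compounds than are shown below. What is called first, only, known or untested is meant among the compounds shown, and "the series" means these compounds.

Compound 3 `O=C(Nc1cc(Sc2ncn[nH]2)c(O)c2ccccc12)c1ccc([N+](=O)[O-])cc1` carries a 4-nitrophenyl on the carbonyl carbon of the shared core. In a functional assay on PC-3 cells (Homo sapiens) for antiproliferative activity, read by MTT assay, with a stated time of 48 h (on this read-out lower numbers stand for stronger inhibition and higher numbers for weaker inhibition), compound 3 gives 53500 nM. Compound 1 `COc1cccc(C(=O)Nc2cc(Sc3ncn[nH]3)c(O)c3ccccc23)c1` gives 42100 nM in this assay, and the step of a 1.3-fold higher number from compound 1 to compound 3 (0.10 log units; within the scatter) lies within the scatter. Compound 2 `COc1ccc(C(=O)Nc2cc(Sc3ncn[nH]3)c(O)c3ccccc23)cc1` reaches only the limit of > 100000 nM in this assay, which is a limit of the assay and not a number. The step of an at least 2.3-fold higher number from compound 1 to compound 2 (0.37 log units; beyond the scatter) lies beyond the scatter, whereas an at least 1.8-fold lower number from compound 2 to compound 3 (0.27 log units; that floor lies within the scatter) has a floor within it. Of the two numbers shown, that of compound 3 is the higher, yet its gap from compound 1 is within the scatter. Compound 4 `O=C(/C=C/c1ccccc1)Nc1cc(Sc2ncn[nH]2)c(O)c2ccccc12` differs from compound 3 in one place: 2-phenylethenyl in place of 4-nitrophenyl on a carbonyl carbon. For the measured compounds named here, no measured step exchanges the group on the carbonyl carbon for a 2-phenylethenyl; the three steps among compounds 1, 2 and 3 all vary that group and move the numbers little, at most by a modest step. Compound 4 is therefore expected to show a step of a 1.2-fold lower number from compound 3 to compound 4 (0.08 log units; within the scatter) in this assay, not beyond the scatter. The estimate for compound 4 is 45000 nM, with a range from 15000 nM to 150000 nM.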

Compound 4, half-maximal inhibitory concentration: > 100000 nM
Compound 4 ended at the assay's limit; the forecaster's own chance of this, stated with the estimate: 30%; at least 2.2-fold (0.34 log units) between middle value and limit.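

In this assay, for the compounds shown here, a second group on this carbonyl carbon now ends at the limit, which is a limit of the assay and not a number, whereas the earlier compounds showed this only for 4-methoxyphenyl: the limit of > 100000 nM in this assay, at which 2 of the 4 values shown sit. Exchanging 3-methoxyphenyl for 2-phenylethenyl gives a clear change, an at least 2.3-fold higher number from compound 1 to compound 4 (0.37 log units; beyond the scatter), while the exchange for 4-nitrophenyl is less firm, an at least 1.8-fold higher number from compound 3 to compound 4 (0.27 log units; that floor lies within the scatter). The step between compound 2 and compound 4 cannot be read, as both stand at the limit.

On these data alone, it remains open whether a 2-phenylethyl chain, which lacks the double bond, would also stay at the limit. As far as these compounds go, it is equally open whether an amine or a carboxylic acid on the aromatic ring of the carbonyl group would move the number away from those of compound 1 and compound 3.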